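The source may hold more compounds than are shown below. What is called first, only, known or untested is meant among the compounds shown, and "the series" means these compounds.

Measured in a functional assay on MGC-803 cells (Homo sapiens) for inhibition, read by MTT assay, with a stated time of 48 h; a lower number here means a stronger inhibitor, a higher number a weaker inhibitor:
- compound 1 `COc1ccc(-c2coc3cc(OCCCSC(=S)N4CCCC4)ccc3c2=O)cc1`: 40000 nM
- compound 2 `COc1ccc(-c2coc3cc(OCCCSC(=S)N4CCOCC4)ccc3c2=O)cc1`: 49600 nM

Within the data shown here, compound 2 stands within the scatter of compound 1, the only other measured compound, so neither stands apart from the other. The next compound is compound 3 `COc1ccc(-c2coc3cc(OCCCCBr)ccc3c2=O)cc1`, and the change from compound 2 is a group of 2 heavy atoms (1 carbon, 1 bromine; no ring) in place of a group of 9 heavy atoms (5 carbon, 1 nitrogen, 1 oxygen, 2 sulfur; one six-membered non-aromatic ring with 2 hetero atoms), on a saturated chain carbon, three bonds along the chain from an oxygen on an aromatic ring. Among the measured compounds shown here, the one measured step, a 1.2-fold higher number from compound 1 to compound 2 (0.09 log units; within the scatter), swaps morpholin-4-yl for pyrrolidin-1-yl on a thiocarbonyl carbon. For the measured compounds named here, it bears only indirectly, since it alters a part of the group that leaves, and no measured compound lacks that group. On that small step, no shift beyond the scatter is expected in this assay, with no direction favoured and a wide margin kept. The estimated change is a 1.2-fold lower number from compound 2 to compound 3 (0.09 log units; within the scatter). For compound 3 the expected value is 40000 nM, with an estimated range of 15000 nM to 100000 nM.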

Compound 3, half-maximal inhibitory concentration: 52700 nM
Compound 3: the middle estimate sits 1.3-fold (0.12 log units) below what was measured; low and high end bracket the measured number.
By their numbers in this assay, from the lowest: compounds 1, 2 and 3 (each within the scatter of the next).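

In this assay, bromomethyl at this place, on a saturated chain carbon, three bonds along the chain from an oxygen on an aromatic ring, gives a 1.1-fold higher number from compound 2 to compound 3 (0.03 log units; within the scatter), and the step from the pyrrolidine-bearing group gives a 1.3-fold higher number from compound 1 to compound 3 (0.12 log units; within the scatter). The whole group carrying the thiocarbonyl, its two sulfur atoms and its ring can therefore be exchanged for bromomethyl with no shift beyond the scatter, so neither that group nor the choice of ring within it is shown to set the number in these three compounds. No measured data bear on the reason for this flat result.

On these data alone, it remains open whether any group at this chain end can move the number beyond the scatter, for example a basic amine such as piperazine or a carboxylic acid. A longer chain and changes on the shared core are equally untested by the compounds shown here.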